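The source may report more compounds than this note shows. Statements on the series, on what has been measured and on what is new or still open speak of the compounds shown alone.

Compound 1 `CC1=CC[C@H](C(C)(C)NC(=S)N/N=C/c2ccccc2)CC1` is the parent of this small set. In a functional assay on NCI/ADR-RES cells (Homo sapiens) for inhibition, read by sulforhodamine B assay, with a stated time of 48 h (a higher number here means a weaker inhibitor of growth, a lower number a stronger inhibitor of growth), compound 1 returns only a limit, > 100000 nM, so its position on the scale is known from one side only. Compound 2 `CC1=CC[C@H](C(C)(C)NC(=S)N/N=C/c2ccc(O)cc2)CC1` carries hydroxy in place of hydrogen on an aromatic carbon and gives 82100 nM in this assay. Compound 3 `CC1=CC[C@H](C(C)(C)NC(=S)N/N=C/c2ccc(F)cc2)CC1` carries fluoro in place of hydrogen on an aromatic carbon; in this assay compound 3 likewise returns only a limit, > 100000 nM. The measured steps are small or unreadable: an at least 1.2-fold lower number from compound 1 to compound 2 (0.08 log units; that floor lies within the scatter), a step that the two limits leave unreadable from compound 1 to compound 3 and an at least 1.2-fold higher number from compound 2 to compound 3 (0.08 log units; that floor lies within the scatter). Two of the three numbers coincide at the limit of > 100000 nM in this assay, at which 2 of the 3 values shown sit, so the series sits at the weak end of what this assay can resolve.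

Compound 4 `CC1=CC[C@H](C(C)(C)NC(=S)N/N=C/c2cccc([N+](=O)[O-])c2)CC1` differs from compound 1 by nitro in place of hydrogen on an aromatic carbon. Going by the values given here, no measured step covers this change; the closest comparisons are the two other single substitutions on the same ring, and the one that can be read at all sits at its floor within the scatter. The expectation is therefore no step beyond the scatter, an at least 1.1-fold lower number from compound 1 to compound 4 (0.04 log units; that floor lies within the scatter), with a real chance that only a limit is reported again. For compound 4 the estimate is 90000 nM, ranging from 30000 nM to 300000 nM.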

Compound 4, concentration for 50% growth inhibition: > 100000 nM
Compound 4: no number, only a limit; the forecaster's own chance of this, stated with the estimate: 60%; middle value at least 1.1-fold (0.04 log units) away from the limit.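

Compound 4 returns > 100000 nM in this assay, a limit and not a number. Compound 1 also returns only a limit, so no step from compound 1 to compound 4 can be read: the limit of > 100000 nM in this assay, at which 3 of the 4 values shown sit.

The compounds shown leave open where compound 1, compound 3 and compound 4 actually lie on the scale of this assay.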